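The compounds below may be only part of what the source reports. "The series", "measured", "known", "first", "only" and "open" are said of these compounds alone.

Measured compounds in a functional assay on MCF7 cells (Homo sapiens) for inhibition, read by MTT assay, with a stated time of 48 h; a lower number here means a stronger inhibitor, a higher number a weaker inhibitor:
compound 1 `Fc1ccc(CSc2nnc(-c3ccncc3)n2-c2ccccc2)cc1` gives 21100 nM
compound 2 `Fc1ccc(CSc2nnc(-c3ccncc3)n2-c2ccccc2)c(F)c1` gives 14100 nM
compound 3 `COc1ccc(/C=N/NC(=O)CSc2nnc(-c3ccncc3)n2-c2ccccc2)cc1` gives 23700 nM

Compound 3 sits alongside compound 1 and compound 2: its gaps to both lie within the scatter, so the three numbers cannot be told apart in this assay.

Compound 4 `O=C(CSc1nnc(-c2ccncc2)n1-c1ccccc1)N/N=C/c1cccc(F)c1` is not yet measured. It differs from compound 3 in one place: 3-fluorophenyl in place of 4-methoxyphenyl on a carbon with a double bond to nitrogen. Going by the values given here, only one measured step exists, a 1.5-fold lower number from compound 1 to compound 2 (0.18 log units; within the scatter), and it concerns a fluoro for hydrogen exchange on the other aromatic ring of the shared core, not the hydrazone aryl group that changes here. It was within the scatter. Among the compounds with values here, no measured pair speaks to the 4-methoxyphenyl to 3-fluorophenyl exchange itself.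

With nothing in the series pointing either way, compound 4 is expected to remain near compound 3 in this assay, and the estimated step of a 1.2-fold lower number from compound 3 to compound 4 (0.07 log units; within the scatter) is expected to fall within the scatter. The estimate for compound 4 is 20000 nM, with a range of 8000 nM to 50000 nM.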

Compound 4, half-maximal inhibitory concentration: > 50000 nM
Compound 4: a limit, no number; the forecaster's own chance of this, stated with the estimate: 15%; middle value at least 2.5-fold (0.39 log units) away from the limit.
By their numbers in this assay, from the lowest: compounds 2, 1 and 3 (each within the scatter of the next). At a limit, above all of these: compound 4.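

In this assay, the aryl group on the carbon with a double bond to nitrogen responds to exchange: 3-fluorophenyl in place of 4-methoxyphenyl gives an at least 2.1-fold higher number from compound 3 to compound 4 (0.32 log units; beyond the scatter), the only step shown beyond the scatter, whereas the earlier step on the other aromatic ring, a 1.5-fold lower number from compound 1 to compound 2 (0.18 log units; within the scatter), stayed within it. Compound 4 gives > 50000 nM, which is a limit of the assay and not a number. The step is therefore only a lower bound on the true size of the change, because the reading stops at the limit: the limit of > 50000 nM in this assay, at which 1 of the 4 values shown sits.

Going by these compounds, whether the shift follows from losing the methoxy, gaining the fluoro, or both stays open, since the two change together here. Also open, on these data alone, is how a plain phenyl or a phenyl carrying an amine would read at this place.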